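The source may report more compounds than this note shows. Statements on the series, on what has been measured and on what is new or still open speak of the compounds shown alone.

Of the compounds shown here, two have so far been measured in an assay on HEK293 cells for displacement of a labelled ligand from D(4) dopamine receptor (Homo sapiens), read by scintillation counting, with a stated time of 60 min; a higher number here means a weaker inhibitor, a lower number a stronger inhibitor. Compound 1 `Cc1cccc(NC(=O)CCN2CCN(c3ccccn3)CC2)c1` gives 297 nM in this assay, the higher of the two numbers and therefore the weaker binder of the pair. Compound 2 `Cc1ccc(C2CCN(CC(=O)Nc3cccc(C)c3)CC2)cc1` gives 110 nM in this assay, a lower number that lies beyond the usual scatter. Compound 2 differs from compound 1 in more than one place, so no single structural step can be read from these two values.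

Compound 3 `Cc1cccc(NC(=O)CCN2CCN(c3ncccn3)CC2)c1` has not yet been measured. It differs from compound 1 by pyrimidin-2-yl in place of pyridin-2-yl on an amine nitrogen in a ring. Going by the values given here, no measured pair shows what this particular change does, and with only two measured compounds there is no anchor for its size. The expectation is a small step, if any, in the direction of a slightly higher number, staying within or only just beyond the scatter, which is expressed as a 1.3-fold higher number from compound 1 to compound 3 (0.13 log units; within the scatter). For compound 3 the expected value in this assay is 400 nM, with a range from 120 nM to 1300 nM.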

Compound 3, inhibition constant: 526 nM
For compound 3 the middle estimate is 1.3-fold (0.12 log units) below the measured one, within the range that was stated.
By their numbers in this assay, from the lowest: compound 2; then compounds 1 and 3 (each within the scatter of the next).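

Going by these compounds alone, replacing pyridin-2-yl with pyrimidin-2-yl on the amine nitrogen of the ring gives, in this assay, a 1.8-fold higher number from compound 1 to compound 3 (0.25 log units; within the scatter) and this is the first step that can be read from a single change. Compound 1 and compound 3 therefore cannot be told apart in this assay, even though the entering ring has 2 hetero atoms and 2 hydrogen-bond acceptors where the leaving ring has 1 of each, so at this position this exchange of one aromatic ring for the other leaves the binding number within the usual scatter. No measurement shown here offers an explanation for the size of this step.

A single exchange between two closely related rings says little about how much room for change this nitrogen allows, and a plain phenyl ring, a pyridin-4-yl ring or a small group such as methyl in the same place could give a very different number. The shared core of compound 1 and compound 3 also has no single-change link to compound 2, so what separates that compound from the other two remains unresolved.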